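Amino for iodo on the aryl ketone of compound 3

The source may hold more compounds than are shown below. What is called first, only, known or untested is meant among the compounds shown, and "the series" means these compounds.

Compound 1 `O=C(/C=C/c1ccc2c(c1)B(O)OC2)c1cccs1` gives 26000 nM in a toxicity assay on WI-38 cells (Homo sapiens) for cytotoxicity, read by MTT assay, with a stated time of 48 h; on this read-out lower numbers stand for stronger inhibition and higher numbers for weaker inhibition. Compound 2 `Cn1cccc1C(=O)/C=C/c1ccc2c(c1)B(O)OC2` reaches only the limit of this assay, > 100000 nM. Compound 3 `O=C(/C=C/c1ccc2c(c1)B(O)OC2)c1ccc(I)cc1` likewise sits at the limit, > 100000 nM. The step of an at least 3.8-fold higher number from compound 1 to compound 2 (0.58 log units; beyond the scatter) and the step of an at least 3.8-fold higher number from compound 1 to compound 3 (0.58 log units; beyond the scatter) both run toward weaker inhibition, while the step that the two limits leave unreadable from compound 2 to compound 3 cannot be read, since (the limit of > 100000 nM in this assay, at which 2 of the 3 values shown sit). Compound 4 `Nc1ccc(C(=O)/C=C/c2ccc3c(c2)B(O)OC3)cc1` carries amino in place of iodo on an aromatic carbon. Within the data shown here, no measured step touches a substituent on this six-membered aromatic ring of carbon only; the steps from compound 1 only exchange the whole group on the carbonyl carbon. With compound 3 at the limit, compound 4 is expected to stay weak, at 100000 nM (range 30000 nM to 300000 nM), a step of a number no higher from compound 3 to compound 4 (the limit leaves the size open) that is estimated rather than measured.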

Compound 4, half-maximal inhibitory concentration: 25400 nM
Compound 4: the middle estimate sits 3.9-fold (0.60 log units) above what was measured; the whole stated range lies above it.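

Amino in place of iodo gives an at least 3.9-fold lower number from compound 3 to compound 4 (0.59 log units; beyond the scatter) in this assay, so a change on this aromatic ring alone, with the rest of the molecule held constant, moves the read-out. The 4-aminophenyl group also gives an at least 3.9-fold lower number from compound 2 to compound 4 (0.59 log units; beyond the scatter) against 1-methyl-1H-pyrrol-2-yl, while a 1.0-fold lower number from compound 1 to compound 4 (0.01 log units; within the scatter) sets it against thiophen-2-yl on the carbonyl carbon. The full size of the first two steps stays open, and the step between compound 2 and compound 3 cannot be read, because those compounds sit at a limit: the limit of > 100000 nM in this assay, at which 2 of the 4 values shown sit.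

Open, on these data alone, is whether a hydroxyl, an acetamide or a dimethylamino group in the same place follows amino or iodo in this assay.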